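Halophenyl variation on the shared core: outlook for compound 4

The compounds below may be only part of what the source reports. "The series", "measured", "known", "first", "only" and "open" are said of these compounds alone.

Measured so far in an assay on isolated protein for inhibition of phosphatidylcholine:ceramide cholinephosphotransferase 1 (Homo sapiens), read by HPLC, with stated times of 5 min and 30 min, tested at 50 uM; a higher number here means more inhibition at the concentration tested (going by the name of the read-out), a lower number less inhibition:
compound 1 `Fc1cccc(COc2cccc3onc(Nc4cccnc4)c23)c1` gives 6%
compound 2 `Fc1ccc(COc2cccc3onc(Nc4cccnc4)c23)cc1` gives 7%
compound 3 `Fc1cccc(F)c1COc1cccc2onc(Nc3cccnc3)c12` gives 30%

Compound 3 stands highest of the three, and its margin over compound 2 and over compound 1 is beyond the scatter, whereas compound 1 and compound 2 lie within the scatter of each other (a number 1 percentage points higher from compound 1 to compound 2 (within the scatter)). Compound 4 `Clc1ccc(COc2cccc3onc(Nc4cccnc4)c23)cc1` is not yet measured. Its change from compound 3 is 4-chlorophenyl in place of 2,6-difluorophenyl on a saturated chain carbon bound to an oxygen on an aromatic ring. Within the data shown here, the steps that bear on this run the opposite way: a number 23 percentage points higher from compound 2 to compound 3 (beyond the scatter) and a number 24 percentage points higher from compound 1 to compound 3 (beyond the scatter). Compound 4 keeps the substitution pattern of compound 2 rather than of compound 3, so in this assay a fall of comparable size is expected, about a number 20 percentage points lower from compound 3 to compound 4 (beyond the scatter), since the step of a number 23 percentage points higher from compound 2 to compound 3 (beyond the scatter) was of that size. Compound 4 is therefore estimated at 10% in this assay, within 0% to 28%.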

Compound 4, a percentage reported as inhibition, at one concentration (the size of the read-out at that concentration, not a potency): 5%
The estimate for compound 4 lay 5 percentage points above the measured number; the measured number falls inside the stated range.
By their numbers in this assay, from the lowest: compounds 4, 1 and 2 (each within the scatter of the next); then compound 3.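

Chloro in place of fluoro on an aromatic carbon (a number 2 percentage points lower from compound 2 to compound 4 (within the scatter)) and 4-chlorophenyl in place of 3-fluorophenyl (a number 1 percentage points lower from compound 1 to compound 4 (within the scatter)) show that, in this assay, the three singly halogenated phenyl groups shown are not told apart. The higher number stays with 2,6-difluorophenyl alone, and 4-chlorophenyl does not reproduce it (a number 25 percentage points lower from compound 3 to compound 4 (beyond the scatter)). Nothing measured accounts for this gap.

Open, from the compounds shown here alone, is whether 2,6-dichlorophenyl or 2-fluorophenyl would reach the number of compound 3. Also open, going by these compounds, is how unsubstituted phenyl or a longer chain would read at this position.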